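This account rests on a few compounds, and the source may have more. Where it says the series, first, only, none or still open, it means among the compounds named here.

Working notes on the trimethoxybenzoyl aminothiophene series, measured in a functional assay on MOLT-4 cells (Homo sapiens) for antiproliferative activity; on this read-out higher numbers stand for weaker inhibition and lower numbers for stronger inhibition.

Compound 1 `COc1cc(C(=O)c2sc(-c3cccs3)cc2N)cc(OC)c1OC` carries a thiophen-2-yl group and gives 8.9 nM. Compound 2 `COc1cc(C(=O)c2sc(-c3ccc(F)cc3)cc2N)cc(OC)c1OC` carries a 4-fluorophenyl group and gives 12 nM; the step from compound 1 to compound 2 is a 1.3-fold higher number from compound 1 to compound 2 (0.13 log units; within the scatter). Among the measured compounds shown here, compound 3 `COc1cc(C(=O)c2sc(-c3ccc([N+](=O)[O-])cc3)cc2N)cc(OC)c1OC` carries a 4-nitrophenyl group and gives 110 nM, the highest of the three numbers measured so far: the step of a 12-fold higher number from compound 1 to compound 3 (1.09 log units; beyond the scatter) and the step of a 9.2-fold higher number from compound 2 to compound 3 (0.96 log units; beyond the scatter) both lie beyond the scatter, so compound 3 is the weakest inhibitor of the three.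

Compound 4 `COc1cc(C(=O)c2sc(-c3ccncc3)cc2N)cc(OC)c1OC` is not yet measured. Compared with compound 3, (pyridin-4-yl in place of 4-nitrophenyl on an aromatic carbon). For the measured compounds named here, of the measured steps, the one from compound 2 to compound 3 bears most directly: a nitro group replaced a fluoro on the same ring with a rise of a 9.2-fold higher number from compound 2 to compound 3 (0.96 log units; beyond the scatter). The step from compound 1 to compound 3, a 12-fold higher number from compound 1 to compound 3 (1.09 log units; beyond the scatter), points the same way. Compound 4 removes the 4-nitrophenyl entirely, so the number is expected to fall back toward those of compound 1 and compound 2, a step estimated at a 5.5-fold lower number from compound 3 to compound 4 (0.74 log units; beyond the scatter). For compound 4 the expected value in this assay is 20 nM, with a range of 7 nM to 60 nM.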

Compound 4, half-maximal inhibitory concentration: 88 nM
Compound 4: middle estimate off by 4.4-fold (0.64 log units), on the low side, and the stated range ends below it.
By their numbers in this assay, from the lowest: compounds 1 and 2 (each within the scatter of the next); then compounds 4 and 3 (each within the scatter of the next).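

In this assay the swap of 4-nitrophenyl for pyridin-4-yl gives a 1.3-fold lower number from compound 3 to compound 4 (0.10 log units; within the scatter) and so shows that, at this position next to the ring sulfur, a number in this range does not depend on a nitro group, since a group without one sits level with compound 3. The same group stands apart from the two low-number compounds, with a 7.3-fold higher number from compound 2 to compound 4 (0.87 log units; beyond the scatter) and a 9.9-fold higher number from compound 1 to compound 4 (1.00 log units; beyond the scatter) as the steps, so the four compounds fall into two sets at this position: compounds 1 and 2 in one, compounds 3 and 4 in the other. Nothing at hand gives a reason for this split.

The compounds shown leave open where an unsubstituted phenyl, a pyridin-3-yl or a 4-methoxyphenyl group would fall relative to these two sets, and so whether the high number of compound 4 goes with the ring nitrogen itself or with its place in the ring. Also open, as far as these compounds go, is whether the split between the two sets holds in cell lines other than this one.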